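The source may report more compounds than this note shows. Statements on the series, on what has been measured and on what is new or still open speak of the compounds shown alone.

In a functional assay on PC-3 cells (Homo sapiens) for cytotoxicity, read by MTT assay, with a stated time of 5 days (on this read-out lower numbers stand for stronger inhibition of growth and higher numbers for weaker inhibition of growth), compound 3 `Cc1ccc(C#N)c(NS(=O)(=O)c2ccc(F)cc2)c1` gives 100000 nM. Its nearest neighbour is compound 1 `Cc1ccc(NS(=O)(=O)c2ccccc2)c([N+](=O)[O-])c1`, which gives 60300 nM, and the gap between these two lies within the usual scatter of repeated measurements, so neither can be ranked over the other. Compound 2 `O=S(=O)(Nc1ccccc1)c1ccccc1` gives > 100000 nM, which is a limit of the assay and not a number. Growth inhibition is therefore weak across everything measured so far, and compound 3 has no clear edge.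

The next molecule, compound 4 `Cc1ccc(-c2nnn[nH]2)c(NS(=O)(=O)c2ccc(F)cc2)c1`, changes one group of compound 3: 1H-tetrazol-5-yl takes the place of cyano on an aromatic carbon. The count for that change is 1H-tetrazol-5-yl in place of cyano on an aromatic carbon. Within the data shown here, no measured pair here shows a swap of this kind, so nothing gives its size directly. An expectation can lean only on the general level set by compound 1 at 60300 nM and compound 3 at 100000 nM. A modest move toward a lower number in this assay, not far beyond the scatter, is expected, and the result could still end at the limit of the assay. The expected change is a 1.8-fold lower number from compound 3 to compound 4 (0.26 log units; within the scatter). For compound 4 the estimated value is 55000 nM, with an expected range from 14000 nM to 130000 nM.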

Compound 4, concentration for 50% growth inhibition: > 100000 nM
Compound 4 gave a limit, no number; the forecaster's own chance of this, stated with the estimate: 35%; at least 1.8-fold (0.25 log units) between middle value and limit.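

Among these compounds, this is the first view of a change at this position, the aromatic carbon ortho to a large group and para to a methyl group. In this assay, replacing cyano with 1H-tetrazol-5-yl, which is a larger group with a ring and a hydrogen-bond donor, brings no detectable gain in growth inhibition. Compound 4 gives > 100000 nM, which is a limit of the assay and not a number. The step is a number no lower from compound 3 to compound 4 (the limit leaves the size open) and its size cannot be read, since the result sits at that limit: the limit of > 100000 nM in this assay, at which 2 of the 4 values shown sit.

The compounds shown leave open whether a different group on this aromatic carbon, such as a carboxylic acid or an amine, could bring the number clearly lower than that of compound 3, which gives 100000 nM. They also leave open whether 1H-tetrazol-5-yl would give the same result on a version of the core without the fluorine on the benzenesulfonyl part, or with a longer chain in place of the methyl group.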